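The source may hold more compounds than are shown below. What is called first, only, known or untested is meant among the compounds shown, and "the series" means these compounds.

In a functional assay on HeLa cells (Homo sapiens) for antiproliferative activity, read by MTT assay, with a stated time of 48 h (on this read-out higher numbers stand for weaker inhibition and lower numbers for stronger inhibition), compound 1 (`Cc1ccc2nc(NC(c3cn(-c4ccccc4)nc3-c3cccc(Cl)c3)c3c(O)ccc4ccccc34)sc2c1`) gives 9430 nM and compound 2 (`Oc1ccc2ccccc2c1C(Nc1nc2ccccc2s1)c1cn(-c2ccccc2)nc1-c1ccccc1`) gives 17300 nM as its value. These two numbers lie within the scatter of each other, so compound 2 stands level with compound 1 and the pair cannot be ranked. Compound 3 (`Cc1cccc(-c2nn(-c3ccccc3)cc2C(Nc2nc3ccccc3s2)c2c(O)ccc3ccccc23)c1`) departs from compound 2 in one place, with methyl in place of hydrogen on an aromatic carbon, phenyl to 3-methylphenyl (methyl in place of hydrogen on an aromatic carbon). Going by the values given here, no two measured compounds differ by this change alone, so the data offer no direct guide to its size. In this assay a shift beyond the scatter is not expected, and no direction can be favoured. The estimated change (a 1.2-fold lower number from compound 2 to compound 3 (0.09 log units; within the scatter)) is accordingly small. Compound 3 is expected to give about 14000 nM with an estimated range from 6500 nM to 30000 nM when it is tested.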

Compound 3, half-maximal inhibitory concentration: 7020 nM
The estimate for compound 3 lay 2.0-fold (0.30 log units) above the measured number; the measured number falls inside the stated range.
By their numbers in this assay, from the lowest: compounds 3, 1 and 2 (each within the scatter of the next, the first and the last beyond it).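

In this assay, methyl in place of hydrogen on an aromatic carbon, meta to a large group, gives a 2.5-fold lower number from compound 2 to compound 3 (0.39 log units; beyond the scatter). This is the first single-place step among these compounds, and it lies beyond the scatter, so the change from phenyl to 3-methylphenyl moves the number towards stronger inhibition, not merely within noise. No measurement at hand speaks to why the number moved.

The compounds shown leave open whether this gain is specific to methyl or would also appear with another group at this place, such as ethyl, methoxy or an amine. Going by these compounds alone, they also leave open whether methyl elsewhere on the same ring would give a step of similar size, as this single pair is the only reading of the change.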